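The source may hold more compounds than are shown below. What is called first, only, known or untested is meant among the compounds shown, and "the series" means these compounds.

In an assay for inhibition of hexokinase-2 (Homo sapiens), read by coupled enzyme assay, with a stated time of 10 min, in the presence of a further agent that is not named here (on this read-out lower numbers stand for stronger inhibition and higher numbers for weaker inhibition), compound 1, with the structure `C=C1CC[C@H]2[C@@](C)(CCC(=O)N[C@@]2(C)COC(=O)c2ccccc2)[C@@H]1/C=C/C1=CCOC1=O`, gives > 50000 nM, which is a limit of the assay and not a number. Compound 2, `C=C1CC[C@H]2[C@@](C)(CCC(=O)N[C@@]2(C)COC(=O)c2ccc([N+](=O)[O-])cc2)[C@@H]1/C=C/C1=CCOC1=O`, differs from it by nitro in place of hydrogen on an aromatic carbon. In this assay compound 2 gives > 50000 nM, again a limit rather than a measured number. The step that the two limits leave unreadable from compound 1 to compound 2 therefore cannot be read; all that the two values show is that both sit at the same limit, as recorded in the limit of > 50000 nM in this assay, at which 3 of the 3 values shown sit. Compound 3, `C=C1CC[C@H]2[C@@](C)(CC[C@@H](OC(=O)c3ccccc3)[C@@]2(C)NC=O)[C@@H]1/C=C/C1=CCOC1=O`, has the same atoms as compound 1 joined differently, and the difference between the two cores is not broken down here. In this assay compound 3 gives > 50000 nM, once more a limit of the assay. Compound 4, `C=C1CC[C@H]2[C@@](C)(CC[C@@H](OC(=O)c3ccc([N+](=O)[O-])cc3)[C@@]2(C)NC=O)[C@@H]1/C=C/C1=CCOC1=O`, has not yet been measured; it differs from compound 3 by nitro in place of hydrogen on an aromatic carbon, the same change as that from compound 1 to compound 2. The expectation for compound 4 rests on compound 3, whose value > 50000 nM is a limit of the assay. It rests also on a step that the two limits leave unreadable from compound 1 to compound 2, which the same change left unreadable. Compound 4 is therefore expected to show a step that the limit leaves unreadable from compound 3 to compound 4, most likely returning only a limit again. The estimate for compound 4 in this assay is 80000 nM, with an expected range from 30000 nM to 300000 nM.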

Compound 4, half-maximal inhibitory concentration: > 50000 nM
Compound 4 ended at the assay's limit (the forecaster's own chance of this, stated with the estimate: 85%); the middle value lies beyond the limit too.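

Compound 4 returns only a limit of the assay, so no step can be read from compound 3 to compound 4, just as none could be read for the same nitro change between compound 1 and compound 2: the limit of > 50000 nM in this assay, at which 4 of the 4 values shown sit. The compounds shown leave open how strongly any of them inhibits the enzyme, and whether the nitro group or the difference between the two cores alters that inhibition at all.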